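Exchanging the Aryl Group of the Ether in Compound 3

This account rests on a few compounds, and the source may have more. Where it says the series, first, only, none or still open, it means among the compounds named here.

Compound 1: `CC(C)C[C@H](N)c1cc(C(F)(F)F)ccc1N1CCN(C(=O)C(C)Cc2ccc(Cl)cc2O)CC1`, which in an assay on HEK293 cells for displacement of a labelled ligand from Melanocortin receptor 4 (Homo sapiens) (a higher number here means a weaker inhibitor, a lower number a stronger inhibitor), gives 36 nM.
Compound 2: `CC(C)C[C@H](N)c1cc(C(F)(F)F)ccc1N1CCN(C(=O)CCC(N)=O)CC1`; in this assay compound 2 reaches only > 10000 nM, a limit of the assay rather than a number.
Compound 3: `CC(C)C[C@H](N)c1cc(C(F)(F)F)ccc1N1CCN(C(=O)COc2ccc(Cl)cc2)CC1`, which in this assay gives 2900 nM.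

Among the two numbers at hand, compound 3 stands highest; its nearest neighbour is compound 1, and the step between them is an 81-fold higher number from compound 1 to compound 3 (1.91 log units; beyond the scatter). The step from compound 2 to compound 3 is an at least 3.4-fold lower number from compound 2 to compound 3 (0.53 log units; beyond the scatter), and it is known only as a bound because of the limit of > 10000 nM in this assay, at which 1 of the 3 values shown sits. The change in compound 1 to compound 2 is an at least 270-fold higher number from compound 1 to compound 2 (2.44 log units; beyond the scatter).

Compound 4 is `Cc1ccc(OCC(=O)N2CCN(c3ccc(C(F)(F)F)cc3[C@@H](N)CC(C)C)CC2)c(C)c1`. Relative to compound 3 it shows (2,4-dimethylphenyl in place of 4-chlorophenyl on an oxygen on a saturated carbon). Within the data shown here, none of the measured steps touches the substituents on the aryl ether; both steps to compound 3 replace the whole group on the carbonyl carbon, so they say little about swapping 4-chlorophenyl for 2,4-dimethylphenyl. The expectation is therefore a step of no size beyond the scatter, in either direction. Compound 4 is estimated at 3000 nM, between 900 nM and 10000 nM, which is expected to amount to a 1.0-fold higher number from compound 3 to compound 4 (0.01 log units; within the scatter).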

Compound 4, inhibition constant: 4000 nM
Compound 4: middle estimate off by 1.3-fold (0.12 log units), on the low side, within the range that was stated.
By their numbers in this assay, from the lowest: compound 1; then compounds 3 and 4 (each within the scatter of the next). At a limit, above all of these: compound 2.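

In this assay the exchange of 4-chlorophenyl for 2,4-dimethylphenyl on the ether oxygen gives a 1.4-fold higher number from compound 3 to compound 4 (0.14 log units; within the scatter) and so the two aryl groups cannot be told apart at this position, even though one carries a chlorine and the other two methyl groups. Among these compounds, this exchange also leaves the ether series far from the group on the carbonyl carbon in compound 1, with a 110-fold higher number from compound 1 to compound 4 (2.05 log units; beyond the scatter) being a large step of the same kind as the one already seen for compound 3. Compound 2 stands at a limit and not at a number, which means that an at least 2.5-fold lower number from compound 2 to compound 4 (0.39 log units; beyond the scatter) can be read only as a bound: the limit of > 10000 nM in this assay, at which 1 of the 4 values shown sits.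

The compounds shown leave open whether the ether position would respond to an aryl ring bearing an amine or a carboxylic acid, or to a pyridine ring in place of the benzene ring. They also leave open which part of the group in compound 1 carries its lower number, the hydroxy group on its ring, the methyl group on its chain or the carbon chain in place of the ether oxygen.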